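The source may hold more compounds than are shown below. What is called first, only, known or untested is meant among the compounds shown, and "the series" means these compounds.

Measured in a functional assay on HUVEC cells (Homo sapiens) for inhibition, with a stated time of 4 days; a higher number here means a weaker inhibitor, a lower number a stronger inhibitor:
- Compound 1 `COc1ccc(C(=O)O)cc1COc1ccc(Cl)c(C)c1`: > 50000 nM
- Compound 2 `COc1ccc(C(N)=O)cc1/C=C\c1ccc(Cl)cc1`: 2900 nM
- Compound 3 `COc1ccc(C(N)=O)cc1/C=C/c1ccccc1`: 2400 nM

Compound 1 gives > 50000 nM, which is a limit of the assay and not a number.

For the measured compounds named here, only two true numbers are therefore available. Compound 2 gives 2900 nM and compound 3 gives 2400 nM, and these two values lie within the scatter of each other. Compound 3 thus stands level with compound 2 in this assay, and it is the starting point for the next comparison.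

Compound 4 `COc1ccc(C(N)=O)cc1/C=C/c1ccc([N+](=O)[O-])cc1` follows from compound 3 by a single change: nitro in place of hydrogen on an aromatic carbon. Nitro takes the place of hydrogen on an aromatic carbon, para to a large group. Going by the values given here, no measured pair in this set isolates a change of this kind, so the expectation rests on little. With compound 3 at 2400 nM as the only anchor, a small move toward a higher number is expected, meaning a slightly weaker inhibitor, and it may well stay within the scatter. The estimated step is a 1.3-fold higher number from compound 3 to compound 4 (0.10 log units; within the scatter). For compound 4 the estimated value is 3000 nM, with an expected range from 800 nM to 12000 nM.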

Compound 4, half-maximal inhibitory concentration: 4700 nM
For compound 4 the middle estimate is 1.6-fold (0.19 log units) below the measured one; the range from low to high includes it.
By their numbers in this assay, from the lowest: compounds 3, 2 and 4 (each within the scatter of the next). At a limit, above all of these: compound 1.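

For the compounds shown here, this pair is the first in the set to isolate a single change, nitro in place of hydrogen on an aromatic carbon, para to a large group, and in this assay it gives a 2.0-fold higher number from compound 3 to compound 4 (0.29 log units; within the scatter). So at this one position, a group of three heavy atoms with two hydrogen-bond acceptors and no net charge replaces a hydrogen atom without moving the result beyond the scatter, and compound 4 still returns a true number, unlike the earlier carboxylic acid with its different linker. Nothing in the data available here accounts for the size of this step, and no measured property bears on this change.

The result rests on one pair, so it cannot say whether the same position would behave alike with an amine, a nitrile or a methyl group, or whether any of these would give a step beyond the scatter. It also leaves open whether nitro would give a similar step elsewhere on this aromatic ring, or on a version of the shared core that carries a different linking chain.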